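Amino substitution on the shared core: compound 3

The source may report more compounds than this note shows. Statements on the series, on what has been measured and on what is new or still open speak of the compounds shown alone.

Measured so far:
compound 1 `ClCc1ccccc1Cn1cnc2c(Cl)nc(Cl)nc21`: 3230 nM
compound 2 `ClCc1ccccc1Cn1cnc2c(Cl)ncnc21`: 11000 nM

In a functional assay on EKVX cells (Homo sapiens) for cytotoxicity, read by sulforhodamine B assay, with a stated time of 48 h (on this read-out higher numbers stand for weaker inhibition of growth and lower numbers for stronger inhibition of growth), compound 1 gives 3230 nM and compound 2 gives 11000 nM. Within the data shown here, compound 2 stands at the higher of the two numbers; the only measured step, a 3.4-fold higher number from compound 1 to compound 2 (0.53 log units; beyond the scatter), is a hydrogen in place of chloro. Compound 3 `Nc1nc(Cl)c2ncn(Cc3ccccc3CCl)c2n1` differs from compound 2 by amino in place of hydrogen on an aromatic carbon, between two ring nitrogen atoms. Among the measured compounds shown here, no measured step covers an amino entering, so the chloro step gives only a sense of scale. A step no larger than modest is expected, direction open, a 1.2-fold lower number from compound 2 to compound 3 (0.09 log units; within the scatter). Compound 3 is estimated at 9000 nM, within 3000 nM to 30000 nM.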

Compound 3, concentration for total growth inhibition: 30900 nM
Compound 3: the middle estimate sits 3.4-fold (0.54 log units) below what was measured; measured number above the stated range.
By their numbers in this assay, from the lowest: compound 1; then compound 2; then compound 3.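

In this assay amino in place of hydrogen on this carbon between two ring nitrogen atoms gives a 2.8-fold higher number from compound 2 to compound 3 (0.45 log units; beyond the scatter) and amino in place of chloro gives a 9.6-fold higher number from compound 1 to compound 3 (0.98 log units; beyond the scatter) on the same carbon. Across the three groups compared here, growth inhibition falls from chloro to hydrogen to amino, and compound 3 is the weakest, with both its steps beyond the scatter. Nothing on hand explains this order.

Still open, on these data alone, is whether a methylamino, dimethylamino or methoxy group on this carbon would fall within this range. Bromo at this place remains open too.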